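The source may report more compounds than this note shows. Statements on the series, on what has been measured and on what is new or still open speak of the compounds shown alone.

Measured compounds:
Compound 1 `CC(C)(C)OC(=O)NC1CCCN(C(=O)CN2CN(c3ccccc3)C3(CCN(C(=O)c4ccc(C5CCCCC5)cc4)CC3)C2=O)C1` gives 4400 nM in an assay on HEK293 cells for displacement of a labelled ligand from NPC1-like intracellular cholesterol transporter 1 (Homo sapiens); a lower number here means a stronger inhibitor, a higher number a weaker inhibitor.
Compound 2 `CC(C)(C)OC(=O)NCCNC(=O)CN1CN(c2ccccc2)C2(CCN(C(=O)c3ccc(C(C)(C)C)cc3)CC2)C1=O` gives 10900 nM in this assay.
Compound 3 `CC(C)(C)OC(=O)NCCNC(=O)CN1CN(c2ccccc2)C2(CCN(C(=O)c3ccc(C4CCCCC4)cc3)CC2)C1=O` gives 5500 nM in this assay.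

Compound 2 carries the highest number of the three; compound 3 stands within the scatter of it, while compound 1 lies beyond it. Compound 4 `CC(C)(C)OC(=O)NCCCNC(=O)CN1CN(c2ccccc2)C2(CCN(C(=O)c3ccc(C(C)(C)C)cc3)CC2)C1=O` differs from compound 2 in one place: ((tert-butoxycarbonyl)amino)methyl in place of (tert-butoxycarbonyl)amino on a saturated chain carbon, two bonds along the chain from an amide-type nitrogen. Among the measured compounds shown here, the only measured step, a 2.0-fold lower number from compound 2 to compound 3 (0.30 log units; within the scatter), concerns the aromatic substituent and not this chain, so no measured step bears on the change. The account therefore expects no movement beyond the scatter in this assay, with the expected step being a 1.1-fold lower number from compound 2 to compound 4 (0.06 log units; within the scatter). Compound 4 is estimated at 9500 nM, within a range from 4000 nM to 23000 nM.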

Compound 4, half-maximal inhibitory concentration: 4500 nM
Compound 4: the middle estimate sits 2.1-fold (0.32 log units) above what was measured; the measured number falls inside the stated range.
By their numbers in this assay, from the lowest: compounds 1, 4, 3 and 2 (each within the scatter of the next, the first and the last beyond it).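

Among the compounds shown here, the chain on the amide-type nitrogen is the first place where a single change moves the number beyond the scatter: in this assay, ((tert-butoxycarbonyl)amino)methyl in place of (tert-butoxycarbonyl)amino gives a 2.4-fold lower number from compound 2 to compound 4 (0.38 log units; beyond the scatter) and so counts as a modest gain. The earlier step concerned the aromatic substituent and stayed within the scatter, so this chain is the more responsive of the two places so far. No available evidence accounts for this step.

Going by these compounds, it remains open whether a longer chain would lower the number further, and whether the gain carries over to the cyclohexyl compounds. On these data alone, the effect of a free amine in place of the carbamate also remains open.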